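Benzyl for butyl on the piperidine of compound 2

The source may hold more compounds than are shown below. What is called first, only, known or untested is meant among the compounds shown, and "the series" means these compounds.

Compound 1: `CCCCN1CCC(C(=O)Nc2cc(Cl)c(N)cc2OC)CC1` — > 10 mg/kg
Compound 2: `CCCCCN1CCC(C(=O)Nc2cc(Cl)c(N)cc2OC)CC1` — > 10 mg/kg

In a functional assay on the whole organism for antagonist activity, with Mus musculus as the target (on this read-out higher numbers stand for an effect only at larger amounts of compound and lower numbers for an effect already at smaller amounts), compound 1 gives only a limit, > 10 mg/kg. In this assay compound 2 likewise gives only a limit, > 10 mg/kg. Among the measured compounds shown here, the step that the two limits leave unreadable from compound 1 to compound 2 is therefore not readable, and the one piece of evidence on hand is the limit of > 10 mg/kg in this assay, at which 2 of the 2 values shown sit, which tells nothing about size or direction.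

Compound 3, `COc1cc(N)c(Cl)cc1NC(=O)C1CCN(Cc2ccc(O)cc2)CC1`, differs from compound 2 by 4-hydroxyphenyl in place of butyl on a saturated chain carbon bound to an amine nitrogen in a ring. For the measured compounds named here, no measured step bears on this exchange: the only step known is the unreadable one, and both measured values are limits. The expectation for compound 3 can rest only on the fact that compound 2 sits at a limit, so the estimated step of an at least 3.3-fold lower number from compound 2 to compound 3 (0.52 log units; beyond the scatter) is wide and uncertain. Compound 3 is estimated at 3 mg/kg, with a range from 0.3 mg/kg to 30 mg/kg, and a real chance that this assay again reports only a limit.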

Compound 3, dose for half-maximal effect: > 8 mg/kg
Compound 3: no number, only a limit; the forecaster's own chance of this, stated with the estimate: 40%; middle value at least 2.6-fold (0.42 log units) from the limit.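

In this assay compound 3 gives only a limit, > 8 mg/kg. Among the compounds shown here, no step among compound 1, compound 2 and compound 3 can therefore be read. The compounds shown leave open at what dose any of them reaches half-maximal effect, and whether 4-hydroxyphenyl in place of butyl changes that dose at all.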